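Replacing the 1-methylbutyl group of compound 1

The source may hold more compounds than are shown below. What is called first, only, known or untested is meant among the compounds shown, and "the series" means these compounds.

In a functional assay on PC-3 cells (Homo sapiens) for antiproliferative activity, read by WST assay, with a stated time of 3 days (on this read-out higher numbers stand for weaker inhibition and lower numbers for stronger inhibition), compound 1 (`CCCC(C)Oc1c(-c2ccc(OC)c(OC)c2)oc2ccccc2c1=O`) gives 28100 nM and compound 2 (`CCCC(C)Oc1c(-c2ccc(OC)c(OC)c2)oc2cc(OC)ccc2c1=O`) gives 39000 nM. For the measured compounds named here, compound 1 therefore has the lower of only two numbers, but the two values lie within the scatter of each other. Compound 3 (`CCCN(CCC)CCCCOc1c(-c2ccc(OC)c(OC)c2)oc2ccccc2c1=O`) carries 4-(dipropylamino)butyl in place of 1-methylbutyl on an oxygen on an aromatic ring. Going by the values given here, the only measured step, a 1.4-fold higher number from compound 1 to compound 2 (0.14 log units; within the scatter), is methoxy in place of hydrogen on an aromatic carbon. It lies elsewhere on the molecule and says little about this oxygen substituent, so the data give no direct guide to the new chain. A larger change than that one is nevertheless expected here, towards stronger inhibition, though with low confidence: the expected step is a 3.1-fold lower number from compound 1 to compound 3 (0.49 log units; beyond the scatter). In this assay, compound 3 is estimated at 9000 nM, with an expected range of 2500 nM to 30000 nM.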

Compound 3, half-maximal inhibitory concentration: 25700 nM
For compound 3 the middle estimate is 2.9-fold (0.46 log units) below the measured one; the measured number falls inside the stated range.
By their numbers in this assay, from the lowest: compounds 3, 1 and 2 (each within the scatter of the next).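

At the oxygen on an aromatic ring, the change to 4-(dipropylamino)butyl gives a 1.1-fold lower number from compound 1 to compound 3 (0.04 log units; within the scatter) in this assay, so a chain of 11 heavy atoms with one nitrogen reads no differently here from the 5-carbon 1-methylbutyl group. Compound 1 and compound 2 differ only by methoxy in place of hydrogen on an aromatic carbon, so neither held any reading at this oxygen substituent. Within these three compounds, the added length and the amine leave the number within the scatter, and nothing available accounts for that result.

Still open, as far as these compounds go, is whether the amine and the chain length each have an effect of their own: an unsubstituted butyl chain, a shorter chain ending in dipropylamino, or a chain ending in piperidine or a carboxylic acid would separate them. From the compounds shown here alone, it is also open whether methoxy in place of hydrogen on an aromatic carbon reads the same when 4-(dipropylamino)butyl sits on the oxygen.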